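This account rests on a few compounds, and the source may have more. Where it says the series, first, only, none or still open, it means among the compounds named here.

Compound 1 `Nc1ncnc2c1c(-c1ccc(Oc3ccccc3)cc1)cn2C[C@H]1CCCN1C(CO)CO`: 28200 nM
Compound 2 `CC(C)(C)c1ccc(C(=O)Nc2cccc(-c3cn([C@H]4CCN(C[C@@H]5CO5)C4)c4ncnc(N)c34)c2)cc1`: 5970 nM
Compound 3 `Nc1ncnc2c1c(-c1cnc3[nH]ccc3c1)cn2C[C@H]1CCCN1C[C@@H]1CO1`: "not determined" (no result reported)

In a functional assay on Daudi cells (Homo sapiens) for antiproliferative activity (a higher number here means a weaker inhibitor, a lower number a stronger inhibitor), compound 1 stands highest of the two numbers, which here means the weaker of the two inhibitors. Its nearest neighbour is compound 2, whose number is lower by a margin beyond the usual scatter. Compound 3 carries no number in this assay.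

Compound 4 `Nc1ncnc2c1c(-c1ccc(Oc3ccccc3)cc1)cn2[C@H]1CCN(C[C@@H]2CO2)C1` is the untested partner of compound 1. The change is 1-((oxiran-2-yl)methyl)pyrrolidin-3-yl in place of (1-(2-hydroxy-1-(hydroxymethyl)ethyl)pyrrolidin-2-yl)methyl on an aromatic nitrogen. Going by the values given here, no measured pair shows this change on its own, so its effect is unknown. Because compound 2 also carries the oxiranylmethylpyrrolidinyl group and gives 5970 nM, a modest move toward a lower number is expected, of about a 2.8-fold lower number from compound 1 to compound 4 (0.45 log units; beyond the scatter). Compound 4 is estimated at 10000 nM, within 3000 nM to 35000 nM.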

Compound 4, half-maximal inhibitory concentration: 5480 nM
Beside the measured number, compound 4's estimate is 1.8-fold (0.26 log units) above it; low and high end bracket the measured number.
By their numbers in this assay, from the lowest: compounds 4 and 2 (each within the scatter of the next); then compound 1.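

With the rest of the molecule unchanged, placing 1-((oxiran-2-yl)methyl)pyrrolidin-3-yl instead of (1-(2-hydroxy-1-(hydroxymethyl)ethyl)pyrrolidin-2-yl)methyl on the aromatic nitrogen gives a 5.1-fold lower number from compound 1 to compound 4 (0.71 log units; beyond the scatter) in this assay. This shows that the group at this position can shift antiproliferative potency by more than the usual scatter. No measurement here explains the shift.

The change alters the ring attachment and the group on the pyrrolidine nitrogen together, so their separate contributions remain unresolved. As far as these compounds go, it is also open how a simple methyl on that nitrogen, or a piperidine ring in place of the pyrrolidine, would behave.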